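Geometry of the exocyclic double bond: compound 2 to compound 4

The source may report more compounds than this note shows. Statements on the series, on what has been measured and on what is new or still open speak of the compounds shown alone.

Three compounds have numbers in a functional assay on the whole organism with Mus musculus as the target; on this read-out lower numbers stand for an effect already at smaller amounts and higher numbers for an effect only at larger amounts of compound. Compound 1 `C/C(=C\C(=O)NC1CC1)c1cccc(F)c1` gives 122 mg/kg in this assay. Compound 2 `NC(=O)/C=C1/CCc2ccc(F)cc21` gives 64 mg/kg, and compound 3 `O=C(/C=C1\CCc2cc(F)cc(F)c21)NC1CC1` gives 69 mg/kg. On this read-out compound 2 has the lowest of the three numbers, but the gap to compound 3 and the gap to compound 1 both lie within the scatter, so the three compounds are not separated here.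

Compound 4 `NC(=O)/C=C1\CCc2ccc(F)cc21` is not yet measured in this assay. Its difference from compound 2 is the two compounds have the same atoms and bonds and differ only in configuration as drawn: 1 of 1 stereo elements differ; a double bond is drawn Z in compound 2 and E in compound 4. Going by the values given here, no step between measured compounds covers such a change, and the three numbers in hand give no direction for it. A step from compound 2 to compound 4 of about the size of the scatter is expected, with no preferred direction; the estimate for compound 4 is 90 mg/kg in this assay, between 30 mg/kg and 270 mg/kg, the expected step being a 1.4-fold higher number from compound 2 to compound 4 (0.15 log units; within the scatter).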

Compound 4, dose for half-maximal effect: 56 mg/kg
For compound 4 the middle estimate is 1.6-fold (0.21 log units) above the measured one, within the range that was stated.
By their numbers in this assay, from the lowest: compounds 4, 2, 3 and 1 (each within the scatter of the next, the first and the last beyond it).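

The earlier compounds shown here differed from each other in more than one place, so none of their gaps could be tied to a single change; this pair isolates one: the fact that compounds 2 and 4 differ only in the configuration as drawn. In this assay the change of the exocyclic double bond from Z to E gives a 1.1-fold lower number from compound 2 to compound 4 (0.06 log units; within the scatter), so the two geometries are not separated on this read-out. This holds for this one pair, with fluorine on the core and an unsubstituted amide, and sets no rule for the series.

Whether the geometry stays equally silent in the cyclopropyl amide of compound 3 remains open, as the compounds shown include no Z and E pair of that amide. Also open, on these data alone, is whether the double bond's geometry would matter with a carboxylic acid in place of the amide, or with a longer chain on it.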